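This account rests on a few compounds, and the source may have more. Where it says the series, first, only, none or still open, it means among the compounds named here.

Compound 1 `COC(=O)C1=C(C)N=C(C)/C(=C(\O)OC)C1c1ccccc1Cl` gives 2.19 nM in a functional assay (muscle tissue) with Cavia porcellus as the target; on this read-out lower numbers stand for an effect already at smaller amounts and higher numbers for an effect only at larger amounts of compound.
Compound 2 `COC(=O)C1=C(C)N=C(C)/C(=C(\O)OC)C1c1ccccc1I` gives 46.8 nM in this assay.
Compound 3 `COC(=O)C1=C(C)N=C(C)/C(=C(\O)OC)C1c1ccccc1C` gives 6.03 nM in this assay.

Among these three, compound 3 stands second highest. Its nearest neighbour is compound 1, a step described as a 2.8-fold higher number from compound 1 to compound 3 (0.44 log units; beyond the scatter), and its furthest is compound 2, a step described as a 7.8-fold lower number from compound 2 to compound 3 (0.89 log units; beyond the scatter). The largest single step in the set, a 21-fold higher number from compound 1 to compound 2 (1.33 log units; beyond the scatter), shows how strongly a change of the group on this aromatic carbon can move the number.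

Compound 4 `CCOc1ccccc1C1C(C(=O)OC)=C(C)N=C(C)/C1=C(\O)OC` has not yet been measured in this assay. It differs from compound 3 in one place: ethoxy in place of methyl on an aromatic carbon. Among the compounds with values here, no measured step introduces an ethoxy group, so the expectation rests only on the two steps that touch the methyl of compound 3. The step from compound 1 to compound 3 and the step from compound 2 to compound 3 together suggest that the group on this carbon matters beyond the scatter, and that a larger group may raise the number. Compound 4 is therefore expected to show a modest rise, a 2.5-fold higher number from compound 3 to compound 4 (0.40 log units; beyond the scatter), with wide uncertainty. The estimate for compound 4 is 15 nM, within a range from 4 nM to 60 nM.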

Compound 4, half-maximal effective concentration: 110 nM
Compound 4: the middle estimate sits 7.3-fold (0.87 log units) below what was measured, outside the stated range (above it).
By their numbers in this assay, from the lowest: compound 1; then compound 3; then compound 2; then compound 4.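

In this assay, putting ethoxy in place of methyl on this aromatic carbon, ortho to a large group, produces a large step (an 18-fold higher number from compound 3 to compound 4 (1.26 log units; beyond the scatter)), so a group that enters through an oxygen and brings three heavy atoms can move the number as strongly as the change from chloro to iodo did. The iodo of compound 2 no longer marks the top of the series: ethoxy goes beyond it (a 2.4-fold higher number from compound 2 to compound 4 (0.37 log units; beyond the scatter)), and the span across this one carbon widens to a new extreme (a 50-fold higher number from compound 1 to compound 4 (1.70 log units; beyond the scatter)), with compound 4 now highest of the four, followed by the iodo, methyl and chloro compounds. Nothing available explains this order, and the result stands as a measured ranking of four groups only.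

The compounds shown leave open whether the rise follows the oxygen or the length of the ethoxy chain, a question that a methoxy group and an ethyl group on the same carbon would help to separate. They also leave open how the number would respond to a longer chain such as propoxy, or to an amine or a hydroxyl group at this place.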